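The source may report more compounds than this note shows. Statements on the series, on what has been measured and on what is new or still open speak of the compounds shown alone.

Working notes on the thiopurine riboside pair in an assay on isolated protein for binding affinity to Equilibrative nucleoside transporter 1 (Homo sapiens); a higher number here means a weaker inhibitor, a lower number a stronger inhibitor. Compound 2 `CCSc1ncnc2c1ncn2[C@@H]1O[C@H](CO)[C@@H](O)[C@H]1O` gives 57500 nM in this assay, the higher of the two numbers on hand. Compound 1 `O=[N+]([O-])c1ccc2c(c1)CCN(c1ncnc3c1ncn3[C@@H]1O[C@H](CO)[C@@H](O)[C@H]1O)C2` gives 182 nM in this assay; the gap between compound 1 and compound 2 lies well beyond the scatter, so compound 2 is the weaker inhibitor of the two by a clear margin. The next compound, compound 3 `Cc1ccc(CSc2ncnc3c2ncn3[C@@H]2O[C@H](CO)[C@@H](O)[C@H]2O)cc1`, differs from compound 2 in one place: 4-methylphenyl in place of methyl on a saturated chain carbon bound to a sulfur. Within the data shown here, no measured step covers this change, so its size has to be estimated from what is at hand. The expectation is a large drop in the number, toward the range of compound 1, so that the step from compound 2 to compound 3 is estimated as a 960-fold lower number from compound 2 to compound 3 (2.98 log units; beyond the scatter) in this assay. Compound 3 is accordingly estimated at 60 nM in this assay, with a range from 8 nM to 500 nM.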

Compound 3, half-maximal inhibitory concentration: 457 nM
Estimate against measurement, compound 3: 7.6-fold (0.88 log units) below; the range from low to high includes it.
By their numbers in this assay, from the lowest: compound 1; then compound 3; then compound 2.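

In this assay, among these compounds, 4-methylphenyl in place of methyl on a saturated chain carbon bound to a sulfur gives a 130-fold lower number from compound 2 to compound 3 (2.10 log units; beyond the scatter) and this is the first step that can be read at this position. It shows that the number in this assay depends strongly on the group carried at this position: the change from ethylsulfanyl to (4-methylbenzyl)sulfanyl brings in one six-membered aromatic ring of carbon only and moves the value well beyond the scatter. Nothing on hand explains the size of this step.

The compounds shown do not separate the contribution of the ring from that of its methyl, a question that plain benzyl would address. Also open, as far as these compounds go, is whether a longer saturated chain such as butyl could stand in for the ring, and how a carboxylic acid or an amine on the ring would read.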